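The source may report more compounds than this note shows. Statements on the series, on what has been measured and on what is new or still open speak of the compounds shown alone.

Compound 1 `Cc1ccccc1Cc1nc2cc(O[C@H]3CC[C@@H](C(=O)O)CC3)ccc2n1C` gives 5400 nM in an assay on isolated protein for inhibition of Long-chain-fatty-acid--CoA ligase 1 (Mus musculus), read by mass spectrometry, with a stated time of 90 min, in the presence of a further agent that is not named here; a lower number here means a stronger inhibitor, a higher number a weaker inhibitor. Compound 2 `Cn1c(Cc2cccnc2)nc2cc(O[C@H]3CC[C@@H](C(=O)O)CC3)ccc21` reaches only the assay limit of > 200000 nM in this assay, so its standing is known as a limit alone. The step of an at least 37-fold higher number from compound 1 to compound 2 (1.56 log units; beyond the scatter) shows the cost of that change, the value resting at the limit of > 200000 nM in this assay, at which 1 of the 2 values shown sits. Compound 3 `Cc1cccc(COc2nc3cc(O[C@H]4CC[C@@H](C(=O)O)CC4)ccc3n2C)c1` carries (3-methylbenzyl)oxy in place of (pyridin-3-yl)methyl on an aromatic carbon. For the measured compounds named here, the single measured step bears on it: it runs the opposite way, carbocycle to pyridine, and was large. A large step toward a lower number is therefore expected, an at least 25-fold lower number from compound 2 to compound 3 (1.39 log units; beyond the scatter), with the altered linker adding uncertainty. Compound 3 is estimated at 8000 nM, within 1500 nM to 60000 nM.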

Compound 3, half-maximal inhibitory concentration: 8100 nM
The estimate for compound 3 lay 1.0-fold (0.01 log units) below the measured number; the range from low to high includes it.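

On the aromatic carbon between two ring nitrogen atoms, (3-methylbenzyl)oxy in place of (pyridin-3-yl)methyl gives an at least 24-fold lower number from compound 2 to compound 3 (1.39 log units; beyond the scatter) in this assay. That step is a bound only, and compound 2 is a limit: the limit of > 200000 nM in this assay, at which 1 of the 3 values shown sits.

Replacing 2-methylbenzyl with (3-methylbenzyl)oxy changes both the link and the methyl place, yet the result stays within the scatter: a 1.5-fold higher number from compound 1 to compound 3 (0.18 log units; within the scatter).

The compounds shown leave open how each of those two changes reads alone. They also leave open how a benzyl ring without methyl, or one carrying an amine, would read in this assay.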